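Working notes: compound 4 as the dimethoxyphenyl analogue of compound 3

A few compounds are considered here, and "the series" means these few. Any claim that something is new, unique, unknown or untested is made for them only; others in the source may bear on it.

The series is followed in an ADME assay on HUVEC cells (Homo sapiens) for antiproliferative activity, read by MTT assay, with a stated time of 48 h; a lower number here means a stronger inhibitor, a higher number a weaker inhibitor. Compound 1 `N#CC1=C(N)Oc2c(c3nc4ccccc4nc3c3ccccc23)C12C(=O)N(Cc1cnnn1-c1ccccc1Cl)c1ccccc12` gives a reading in this assay that is only a limit of the assay and not a number, > 50000 nM. Compound 2 `N#CC1=C(N)Oc2c(c3nc4ccccc4nc3c3ccccc23)C12C(=O)N(Cc1cnnn1-c1cc(Cl)ccc1Cl)c1ccccc12` likewise gives only a limit in this assay, > 50000 nM. Among the compounds with values here, the one step between measured compounds, chloro in place of hydrogen on an aromatic carbon, therefore has no readable size: a step that the two limits leave unreadable from compound 1 to compound 2. Compound 3 `Cc1cccc(-n2nncc2CN2C(=O)C3(C(C#N)=C(N)Oc4c(N)cc5nc6ccccc6nc5c43)c3ccccc32)c1` also stands at a limit in this assay, > 50000 nM. Within the data shown here, every reading so far thus sits at the same place, (the limit of > 50000 nM in this assay, at which 3 of the 3 values shown sit), and no measured step offers a usable size.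

Compound 4 `COc1ccc(OC)c(-n2nncc2CN2C(=O)C3(C(C#N)=C(N)Oc4c(N)cc5nc6ccccc6nc5c43)c3ccccc32)c1` differs from compound 3 by 2,5-dimethoxyphenyl in place of 3-methylphenyl on an aromatic nitrogen. Among the measured compounds shown here, no measured step covers this change, and the step between compound 1 and compound 2 cannot be read, so there is no basis for expecting a shift in either direction. Because the limit of > 50000 nM in this assay, at which 3 of the 3 values shown sit, holds for all values shown, compound 4 is expected to give a reading that again sits at the limit of this assay. The step from compound 3 to compound 4 is expected to be about a step that the limit leaves unreadable from compound 3 to compound 4. The estimate for compound 4 is 70000 nM, in a range from 30000 nM to 200000 nM, with the most likely outcome being that only a limit is reported.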

Compound 4, half-maximal inhibitory concentration: > 50000 nM
Compound 4: only a limit was reported; the forecaster's own chance of this, stated with the estimate: 85%; the middle value does not contradict the limit.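

No new step can be read between compound 3 and compound 4 in this assay, and the same holds for every pair in the series, whose readings are all a limit of the assay and not a number: the limit of > 50000 nM in this assay, at which 4 of the 4 values shown sit.

The compounds shown leave open what change to the shared core or to the group on the aromatic nitrogen would bring a numerical reading in this assay and how large any step would be.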